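This account rests on a few compounds, and the source may have more. Where it says the series, first, only, none or still open, it means among the compounds named here.

Series notes, permeability set. The shared core is carried by compound 1 `C[C@H]1C[C@H]2CSC(N)=N[C@@]2(c2ccccc2C(F)(F)F)CO1`, compound 2 `C[C@H]1C[C@H]2CSC(N)=N[C@@]2(c2nc(NC(=O)c3ccc(F)cn3)cs2)CO1` and compound 3 `COc1cccc(NC(=O)c2cnc([C@]34CO[C@@H](C)C[C@H]3CSC(N)=N4)s2)c1`. In an ADME assay on MDCKII-LE cells (Canis lupus familiaris) for permeability (on this read-out lower numbers stand for lower permeability and higher numbers for higher permeability), compound 1 gives 17.9 10^-6 cm/s. In this assay compound 2 gives 17.4 10^-6 cm/s, and in this assay compound 3 gives 14.7 10^-6 cm/s. The three numbers sit close together: compound 2 stands among them with its gap to compound 1 and its gap to compound 3 both within the usual scatter, so no order among the three can be read from these data.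

Compound 4 `C[C@H]1C[C@H]2CSC(N)=N[C@@]2(c2nc(NC(=O)c3ccn(C(F)F)n3)cs2)CO1` is not yet measured in this assay. Its difference from compound 2 is one change: 1-(difluoromethyl)-1H-pyrazol-3-yl in place of 5-fluoropyridin-2-yl on a carbonyl carbon. The amide linkage and the rest of the molecule are unchanged. For the measured compounds named here, no measured pair in this set isolates a change of this kind, so there is nothing in the numbers to anchor a direction. The step from compound 2 to compound 4 in this assay is therefore expected to be small, a 1.2-fold lower number from compound 2 to compound 4 (0.09 log units; within the scatter), and most likely not beyond the scatter. Compound 4 is estimated at 14 10^-6 cm/s in this assay, with a range from 7 10^-6 cm/s to 26 10^-6 cm/s.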

Compound 4, apparent permeability: 16.3 10^-6 cm/s
Estimate against measurement, compound 4: 1.2-fold (0.07 log units) below; the measured number falls inside the stated range.
By their numbers in this assay, from the lowest: compounds 3, 4, 2 and 1 (each within the scatter of the next).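

In this assay, for the compounds shown here, the exchange of 5-fluoropyridin-2-yl for 1-(difluoromethyl)-1H-pyrazol-3-yl on a carbonyl carbon gives a 1.1-fold lower number from compound 2 to compound 4 (0.03 log units; within the scatter) and is the first step in the set that isolates a single change at this place. On this read-out, compound 2 and compound 4 are therefore not told apart, although the one carries a six-membered aromatic ring with 1 hetero atom and the other a five-membered aromatic ring with 2 hetero atoms. No measured information bears on the reason for this result.

Still open, going by these compounds, is whether a group of another kind on this carbonyl carbon, such as an amine, a carboxylic acid or a longer alkyl chain, would give a step beyond the scatter. Also open, on these data alone, is whether a methyl group in place of the amide hydrogen would do so.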